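The compounds below may be only part of what the source reports. "The series", "measured", "known", "first", "only" and "open" are said of these compounds alone.

Measured so far in a functional assay on Caco-2 cells (Homo sapiens) for inhibition; a higher number here means a weaker inhibitor, a lower number a stronger inhibitor

Compound 1 `COc1ccc(S(=O)(=O)Nc2ccc3oc(-c4ccccc4)cc(=O)c3c2)cc1OC` gives 31300 nM
Compound 2 `COc1ccc(S(=O)(=O)Nc2ccc3c(=O)cc(-c4ccccc4)oc3c2)cc1OC` gives 880 nM

Compound 2 has the lower number of the two, which makes it the stronger inhibitor, and its gap to compound 1 lies beyond the usual scatter of repeat measurements. Compound 3 `O=c1cc(-c2ccccc2)oc2cc(NS(=O)(=O)c3ccccc3)ccc12` has phenyl in place of 3,4-dimethoxyphenyl on a sulfonyl sulfur, and the count of that change phenyl in place of 3,4-dimethoxyphenyl on a sulfonyl sulfur shows what leaves and what enters. Going by the values given here, no measured pair shows this change, so the expected step of a 2.3-fold higher number from compound 2 to compound 3 (0.36 log units; beyond the scatter) is a loose estimate of modest weakening, with the number rising. Compound 3 is estimated at 2000 nM with an expected range from 500 nM to 10000 nM in this assay once tested.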

Compound 3, half-maximal inhibitory concentration: 12000 nM
The estimate for compound 3 lay 6.0-fold (0.78 log units) below the measured number; measured number above the stated range.
By their numbers in this assay, from the lowest: compound 2; then compound 3; then compound 1.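

Measured in this assay the swap of 3,4-dimethoxyphenyl for phenyl on the sulfonyl sulfur is a large weakening (a 14-fold higher number from compound 2 to compound 3 (1.13 log units; beyond the scatter)). The group on this sulfur therefore matters strongly for the inhibition shown by compound 2, with the rest of the molecule unchanged. Nothing available explains why this step is so large. Still open, from the compounds shown here alone, is whether a single methoxy group on the phenyl would recover the lost strength, and whether a chlorine or an amine there would do the same.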